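From 4-fluorobenzyl to 2,4-difluorobenzyl: stability notes

This account rests on a few compounds, and the source may have more. Where it says the series, first, only, none or still open, it means among the compounds named here.

Three compounds with the shared core have entries in an ADME assay on microsomes from liver (Homo sapiens) for metabolic stability, with a stated time of 30 min (a lower number here means that less of the compound is left, a higher number that more of the compound is left), and only one of them has a number. For compound 1 `COc1nc2c(cc1Nc1ccc(F)cc1)c(=O)c(C(=O)O)cn2[C@H](CO)C(C)C` the entry reads "not determined" (no result reported) and for compound 2 `COc1nc2c(cc1NCc1cccc(Cl)c1F)c(=O)c(C(=O)O)cn2[C@H](CO)C(C)C` it reads "not determined" (no result reported) so neither can serve as a comparison. Within the data shown here, compound 3 `COc1nc2c(cc1NCc1ccc(F)cc1)c(=O)c(C(=O)O)cn2[C@H](CO)C(C)C` gives 87% as the single value, so it cannot yet be ranked against any other compound.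

Compound 4 `COc1nc2c(cc1NCc1ccc(F)cc1F)c(=O)c(C(=O)O)cn2[C@H](CO)C(C)C` differs from compound 3 by fluoro in place of hydrogen on an aromatic carbon in one place. This is fluoro in place of hydrogen on an aromatic carbon, ortho to a large group and meta to a fluoro group. The same difference reads 4-fluorobenzyl to 2,4-difluorobenzyl.

Among the measured compounds shown here, no measured pair shows the size of such a step. The expectation therefore rests on compound 3 alone, at 87% in this assay as the only anchor. The expected step of a number 2 percentage points lower from compound 3 to compound 4 (within the scatter) is small and stays within the usual scatter, with no firm direction. For compound 4 the estimate is 85% with an expected range from 70% to 96% in this read-out.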

Compound 4, percent of the compound remaining: 87%
The estimate for compound 4 lay 2 percentage points below the measured number; the range from low to high includes it.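

In this assay, among these compounds, the series gains its first readable step, no change at the digits printed from compound 3 to compound 4 (within the scatter), so fluoro in place of hydrogen on an aromatic carbon, ortho to a large group and meta to a fluoro group, now has a measured size where the earlier compounds offered only a single number. The change from 4-fluorobenzyl to 2,4-difluorobenzyl therefore shows no difference beyond the scatter in the percent of compound remaining, and this holds for this one pair only, with no wider pattern to be drawn from it. No accompanying measurement bears on the origin of this result.

Steps involving compound 1 and compound 2 cannot be read, since their entries carry no number, which leaves the (4-fluorobenzyl)amino part of compound 3 without a comparison to either of those two groups. Also open, going by these compounds, is whether a different group at this same place on the ring, such as chloro, methoxy or a nitrile, would give a step beyond the scatter, and whether the same holds once the carboxylic acid of the shared core is replaced by an amide.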